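Pyrimidin-2-yl for 5-methyl-1,3-thiazol-2-yl in compound 2

This account rests on a few compounds, and the source may have more. Where it says the series, first, only, none or still open, it means among the compounds named here.

Among the compounds with values here, in a toxicity assay on HepG2 2.2.15 cells (Homo sapiens) for cytotoxicity, read by CellTiter-Glo (a higher number here means that more compound is tolerated, a lower number that less compound is tolerated), compound 1 (`O=C1NC(c2ccccc2)CN1c1cnn2c1CN(C(=O)Nc1cc(F)c(F)c(F)c1)C(C1CC1)C2`) gives 38500 nM, and compound 2 (`Cc1cnc(C2CC(=O)N(c3cnn4c3CN(C(=O)Nc3cc(F)c(F)c(F)c3)C(C3CC3)C4)C2)s1`) gives 96200 nM, the higher of the two numbers so far.

The next structure, compound 3 (`O=C1CC(c2ncccn2)CN1c1cnn2c1CN(C(=O)Nc1cc(F)c(F)c(F)c1)C(C1CC1)C2`), carries pyrimidin-2-yl in place of 5-methyl-1,3-thiazol-2-yl on a saturated ring carbon, and the rest of the molecule is unchanged: pyrimidin-2-yl in place of 5-methyl-1,3-thiazol-2-yl on a saturated ring carbon.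

Within the data shown here, only one measured step bears on this, and only indirectly: a 2.5-fold higher number from compound 1 to compound 2 (0.40 log units; beyond the scatter). That step exchanged the whole 2-oxo-4-phenylimidazolidin-1-yl group for 4-(5-methyl-1,3-thiazol-2-yl)-2-oxopyrrolidin-1-yl, whereas the new change leaves the 2-oxopyrrolidin-1-yl part in place. Among the measured compounds shown here, no measured pair isolates the exchange at hand, so the direction is poorly defined.

A smaller step than the modest one already seen is expected, with a slight lean to a lower number. The expected change is a 1.1-fold lower number from compound 2 to compound 3 (0.05 log units; within the scatter), a step estimated to stay within the scatter. In this assay the estimated value for compound 3 is 85000 nM, with an expected range from 40000 nM to 140000 nM.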

Compound 3, half-maximal cytotoxic concentration: > 200000 nM
Compound 3 ended at the assay's limit; the forecaster's own chance of this, stated with the estimate: 35%; at least 2.3-fold (0.37 log units) between middle value and limit.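

Compound 3 stands at a limit of this assay, which is not a number: the limit of > 200000 nM in this assay, at which 1 of the 3 values shown sits.

Read as a bound, the exchange at this saturated ring carbon, with the 2-oxopyrrolidin-1-yl part kept, gives an at least 2.0-fold higher number from compound 2 to compound 3 (0.31 log units; beyond the scatter) and so is the first measured step that isolates the aromatic group alone, showing that this position is not indifferent to the swap of 5-methyl-1,3-thiazol-2-yl for pyrimidin-2-yl. Going by these compounds, the exchange of the whole group gives an at least 5.1-fold higher number from compound 1 to compound 3 (0.71 log units; beyond the scatter) as a second bound, so both compounds carrying a substituted 2-oxopyrrolidin-1-yl group sit on the higher side of compound 1 in this assay and the true size of both new steps remains unknown.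

The compounds shown leave open how far beyond the limit compound 3 lies, and no cause for the shift can be assigned from them. Pyridin-2-yl or unmethylated thiazol-2-yl at the same saturated ring carbon would help separate the contribution of the pyrimidine ring from the loss of the sulfur or the methyl group.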